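From compound 2 to compound 4: a benzyl swap

The source may hold more compounds than are shown below. What is called first, only, known or untested is meant among the compounds shown, and "the series" means these compounds.

In a functional assay on SK-HEP1 cells (Homo sapiens) for inhibition, read by sulforhodamine B assay, with a stated time of 48 h (on this read-out lower numbers stand for stronger inhibition and higher numbers for weaker inhibition), compound 2 `O=C(CCCCC(=O)Nc1ccc(NC(=O)Nc2ccc(Cl)c(C(F)(F)F)c2)cc1)NO` gives > 10000 nM, which is a limit and not a number. Compound 1 `O=C(CCCC(=O)Nc1ccc(NC(=O)Nc2ccc(Cl)c(C(F)(F)F)c2)cc1)NO` gives > 10000 nM, which is also a limit. Among the measured compounds shown here, compound 3 `O=C(CCCCCCC(=O)Nc1ccc(NC(=O)Nc2ccc(Cl)c(C(F)(F)F)c2)cc1)NO` gives 8100 nM, the only true number so far. What the series shows so far is therefore (the limit of > 10000 nM in this assay, at which 2 of the 3 values shown sit).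

Compound 4 `O=C(Nc1ccc(NCc2ccc(C(=O)NO)cc2)cc1)Nc1ccc(Cl)c(C(F)(F)F)c1` carries 4-(hydroxycarbamoyl)benzyl in place of (4-(hydroxycarbamoyl)butyl)carbonyl on a nitrogen on an aromatic ring. The measured steps change only the chain: there is a step that the two limits leave unreadable from compound 1 to compound 2, then an at least 1.2-fold lower number from compound 2 to compound 3 (0.09 log units; that floor lies within the scatter), and an at least 1.2-fold lower number from compound 1 to compound 3 (0.09 log units; that floor lies within the scatter). None of them brings in a ring, so they are a weak guide to this change. With compound 3 at 8100 nM as the one firm anchor, only a modest move toward lower numbers is expected. The result could again be a limit. The expected step is an at least 1.6-fold lower number from compound 2 to compound 4 (0.22 log units; that floor lies within the scatter). For compound 4 the estimated value is 6000 nM, with an expected range from 2000 nM to 18000 nM.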

Compound 4, half-maximal inhibitory concentration: 7200 nM
Compound 4: middle estimate off by 1.2-fold (0.08 log units), on the low side; measured number inside the range.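

Among the compounds shown here, compound 4 shows that a group holding a six-membered aromatic ring can replace the open chain on this nitrogen and still give a true number in this assay, whereas all the earlier compounds carry open chains there. Against those chains, the readable steps are an at least 1.3-fold lower number from compound 2 to compound 4 (0.14 log units; that floor lies within the scatter) and an at least 1.3-fold lower number from compound 1 to compound 4 (0.14 log units; that floor lies within the scatter) in this comparison. They can be read only as floors, because compound 1 and compound 2 sit at a limit: the limit of > 10000 nM in this assay, at which 2 of the 4 values shown sit.

On these data alone, how far compound 4 really lies from compound 2 stays open, so the data do not show whether the ring change helps at all. Also open, as far as these compounds go, is how this assay would read a carboxylic acid in place of the hydroxycarbamoyl group, or a 4-(hydroxycarbamoyl)benzoyl group on this nitrogen.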